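The compounds below may be only part of what the source reports. "The series", "measured", "known", "first", "only" and "open" are said of these compounds alone.

In a functional assay on ECV-304 cells (Homo sapiens), with stated times of 30 min and 6 h (a lower number here means that less compound is needed, a higher number that more compound is needed for the effect), compound 2 `Cc1nc(C)c(CN2CCN(C(=O)CCc3ccccc3)CC2)nc1C` gives 150000 nM, the lowest number of the two compounds with a result. Compound 1 `COc1cccc(/C=C/C(=O)N2CCN(Cc3nc(C)c(C)nc3C)CC2)c1OC` gives 340000 nM in this assay, a higher number than compound 2 by a margin beyond the usual scatter. For compound 3 `Cc1ccc(S(=O)(=O)N2CCN(Cc3nc(C)c(C)nc3C)CC2)cc1` the entry in this assay is "not determined" (no result reported), so no result was reported for it. Compound 4 `CCOC(=O)N1CCN(Cc2nc(C)c(C)nc2C)CC1` differs from compound 2 in a single place: ethoxy in place of phenethyl on a carbonyl carbon. Within the data shown here, no measured pair in this set carries such a change, so its direction can only be guessed from the sparse numbers at hand. The expected step is a 2.0-fold higher number from compound 2 to compound 4 (0.30 log units; within the scatter), toward a higher number, though a change no larger than the scatter would not surprise. The estimate for compound 4 in this assay is 300000 nM, with a range from 100000 nM to 1000000 nM.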

Compound 4, half-maximal effective concentration: 76600 nM
Estimate against measurement, compound 4: 3.9-fold (0.59 log units) above; measured number outside the range, below it.
By their numbers in this assay, from the lowest: compounds 4 and 2 (each within the scatter of the next); then compound 1.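

In this assay, ethoxy in place of phenethyl on a carbonyl carbon gives a 2.0-fold lower number from compound 2 to compound 4 (0.29 log units; within the scatter) and so shows that the aromatic ring of phenethyl can leave this position without a change beyond the scatter. The position therefore accepts both a chain with an aromatic ring and a short group with an oxygen on the carbonyl carbon. Nothing at hand explains this result. Going by these compounds, it remains open whether an amine or a longer chain on this carbonyl carbon would shift the number beyond the scatter.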